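From a Hydroxyl Chain to a Pyridine Arm

The source may report more compounds than this note shows. Statements on the series, on what has been measured and on what is new or still open speak of the compounds shown alone.

Compound 2 `O=C(NCCO)c1ccc2ccc(C(=O)c3ccccc3)c-2cc1` stands highest of the three compounds measured in a physicochemical assay for lipophilicity, read by HPLC, measured as octanol-water partition, at pH 11 (on this read-out higher numbers stand for higher lipophilicity and lower numbers for lower lipophilicity), and compound 2 gives 2.2. Compound 3 `O=C(Nc1cc2cccccc-2c1)c1cccnc1` comes nearest, and in this assay compound 3 gives 1.3, a gap beyond the usual scatter. Compound 1 `Cn1c(NC(=O)c2cccnc2)cc2ccccc21` lies furthest away, and in this assay compound 1 gives -0.1, again well beyond the scatter. Compound 4 `O=C(NCc1cccnc1)c1ccc2ccc(C(=O)c3ccccc3)c-2cc1` has not yet been measured. It differs from compound 2 in a single place: pyridin-3-yl in place of hydroxymethyl on a saturated chain carbon bound to an amide-type nitrogen. For the measured compounds named here, no pair of measured compounds differs by exactly this change, so the three known numbers cannot show directly what it does. Going by the change itself, a step upward of moderate size, beyond the scatter, is expected a number 1.10 log units higher from compound 2 to compound 4 (beyond the scatter). Compound 4 is therefore expected to give about 3.3 in this assay, with a likely range from 2.6 to 4.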

Compound 4, distribution coefficient: 1.4
The estimate for compound 4 lay 1.90 log units above the measured number; measured number below the stated range.
By their numbers in this assay, from the lowest: compound 1; then compounds 3 and 4 (each within the scatter of the next); then compound 2.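

For the compounds shown here, this is the first direct reading of this change: in this assay, putting pyridin-3-yl in place of hydroxymethyl on a saturated chain carbon bound to an amide-type nitrogen gives a number 0.80 log units lower from compound 2 to compound 4 (beyond the scatter) on an otherwise shared core. The entering group has more heavy atoms, a ring and no hydrogen-bond donor, yet the number falls, so a simple count of those features does not give the direction of the step at this position. No measurement shown here accounts for the fall.

Whether the fall is tied to the ring nitrogen of pyridin-3-yl remains open, since a plain phenyl group on the same chain carbon does not appear among these compounds. From the compounds shown here alone, how an amine, a carboxylic acid or a longer chain at this place would read also remains unknown.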